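Ketone side-chain exchange in a carboxyphenyl ether series

The source may hold more compounds than are shown below. What is called first, only, known or untested is meant among the compounds shown, and "the series" means these compounds.

Measured so far:
compound 1 `Cc1c(OCCCCOc2ccccc2C(=O)O)ccc(C(=O)CC(C)C)c1O` – 415 nM
compound 2 `Cc1c(OCCCCOc2cccc(C(=O)O)c2)ccc(C(=O)CC(C)C)c1O` – 222 nM
compound 3 `Cc1c(OCCCCOc2ccc(C(=O)O)cc2F)ccc(C(=O)CC2CCCC2)c1O` – 639 nM

In an assay on HEK293 cells for positive allosteric modulation of metabotropic glutamate receptor 2 (Rattus norvegicus), read by thallium flux, with a stated time of 2.5 min (on this read-out higher numbers stand for an effect only at larger amounts of compound and lower numbers for an effect already at smaller amounts), compound 3 shows the largest of the three values. Its gap to compound 1 lies within the scatter, whereas compound 2 sits a step beyond the scatter below it. Among the compounds with values here, the one step that can be taken cleanly, a 1.9-fold lower number from compound 1 to compound 2 (0.27 log units; within the scatter), concerns only the carboxyphenyl ring and gives no guidance on the ketone side chain.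

Compound 4 `Cc1c(OCCCCOc2ccc(C(=O)O)cc2F)ccc(C(=O)CC(C)C)c1O` keeps the aryl ether of compound 3 and differs in that side chain alone: isopropyl in place of cyclopentyl on a saturated chain carbon bound to a carbonyl carbon. Within the data shown here, no measured pair isolates this exchange. What can be said is that compounds 1 and 2 both carry the isobutylcarbonyl chain that compound 4 acquires; compound 1 gives 415 nM and compound 2 gives 222 nM, both in the same region as compound 3 or somewhat lower. Among the measured compounds shown here, with no direct precedent, the expected step for compound 4 is none beyond the scatter, a 1.6-fold lower number from compound 3 to compound 4 (0.20 log units; within the scatter), with some lean toward the lower side. Compound 4 is therefore estimated at 400 nM, in a range from 150 nM to 1000 nM.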

Compound 4, half-maximal effective concentration: 102 nM
Estimate against measurement, compound 4: 3.9-fold (0.59 log units) above; the measured number lies below the stated range.
By their numbers in this assay, from the lowest: compound 4; then compounds 2, 1 and 3 (each within the scatter of the next, the first and the last beyond it).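

In this assay, the saturated chain carbon bound to a carbonyl carbon is now shown to be a place where the choice of group changes the read-out: with the 4-carboxy-2-fluorophenyl ether held fixed, isopropyl in place of cyclopentyl gives a 6.3-fold lower number from compound 3 to compound 4 (0.80 log units; beyond the scatter), the first reading of this exchange in the series. Within the data shown here, with the isobutylcarbonyl chain held fixed, the aryl ether also separates for the first time, since 4-carboxy-2-fluorophenyl gives a 2.2-fold lower number from compound 2 to compound 4 (0.34 log units; beyond the scatter) against 3-carboxyphenyl and a 4.1-fold lower number from compound 1 to compound 4 (0.61 log units; beyond the scatter) against 2-carboxyphenyl, whereas those two earlier rings lie within the scatter of each other. Compound 4 therefore has the lowest number of the four, with its steps to all three others beyond the scatter.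

Still open are how a cyclobutyl or a tert-butyl group would read at this chain carbon, and whether an unfluorinated 4-carboxyphenyl ring would read with compound 4 or with compound 2, as the ring exchanges shown move the carboxyl group and add fluorine together. Nothing available accounts for the size of either the side-chain step or the ring steps.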